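One Halogen Swap, Tried Twice in a Cell Assay

A few compounds are considered here, and "the series" means these few. Any claim that something is new, unique, unknown or untested is made for them only; others in the source may bear on it.

Three compounds sharing one core were tested in a functional assay on MCF7 cells (Homo sapiens) for inhibition, read by sulforhodamine B assay, with a stated time of 48 h, tested at 10 uM; a lower number here means a stronger effect, a higher number a weaker effect of the compound at the concentration tested. Compound 1 `O=C(Nc1cccc(-n2cc(-c3ccncc3)c(-c3cc(O)cc(Cl)c3)n2)c1)Nc1ccc(Cl)c(C(F)(F)F)c1` gives 13.4%. Compound 2 `O=C(Nc1cccc(-n2cc(-c3ccncc3)c(-c3cc(O)cc(Cl)c3)n2)c1)Nc1ccc(Cl)c(Cl)c1` gives 2.74%, and compound 3 `COc1cc(Cl)cc(-c2nn(-c3cccc(NC(=O)Nc4ccc(Cl)c(C(F)(F)F)c4)c3)cc2-c2ccncc2)c1` gives 2.57%. Compound 2 differs from compound 1 by chloro in place of trifluoromethyl on an aromatic carbon, a change that brought a number 10.7 percentage points lower from compound 1 to compound 2 (beyond the scatter). Compound 3 differs from compound 1 by methyl in place of hydrogen on an oxygen on an aromatic ring, and that change brought a number 10.8 percentage points lower from compound 1 to compound 3 (beyond the scatter). Compound 2 and compound 3 lie within the scatter of each other, so no order between them is drawn.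

Compound 4 `COc1cc(Cl)cc(-c2nn(-c3cccc(NC(=O)Nc4ccc(Cl)c(Cl)c4)c3)cc2-c2ccncc2)c1` has not yet been measured. Among the compounds with values here, it differs from compound 3 by chloro in place of trifluoromethyl on an aromatic carbon, which is the same change as the one from compound 1 to compound 2, now made on the core of compound 3; the surroundings of the place are described in the same words in both cases. A further fall of the earlier size is not expected, because compound 3 already stands at 2.57% and the read-out cannot fall much further. The expected step is therefore a number 1.1 percentage points lower from compound 3 to compound 4 (within the scatter), clearly smaller than the earlier one. Compound 4 is expected to give 1.5%, likely between -6% and 9%.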

Compound 4, a percentage reported as activity, at one concentration (the size of the read-out at that concentration, not a potency): 4.66%
Compound 4: the middle estimate sits 3.2 percentage points below what was measured; the range from low to high includes it.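

On the core of compound 3, chloro in place of trifluoromethyl brought a number 2.1 percentage points higher from compound 3 to compound 4 (within the scatter), yet in this assay this step cannot be told apart from the one made on the core of compound 1: the same change on two cores in this assay, a number 10.7 percentage points lower (beyond the scatter) from compound 1 to compound 2 and a number 2.1 percentage points higher (within the scatter) from compound 3 to compound 4, 12.8 percentage points apart, within the scatter of two such steps. Likewise, methyl in place of hydrogen on the oxygen brought a number 1.9 percentage points higher from compound 2 to compound 4 (within the scatter), and this step cannot be told apart from the earlier one either: the same change on two cores in this assay, a number 10.8 percentage points lower (beyond the scatter) from compound 1 to compound 3 and a number 1.9 percentage points higher (within the scatter) from compound 2 to compound 4, 12.8 percentage points apart, within the scatter of two such steps. Within the data shown here, the two cores therefore show no conflict, but this does not show that either change carries over, as the only steps beyond the scatter start from compound 1, while compound 2, compound 3 and compound 4 all lie within the scatter of one another, with little room left for a further fall.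

The compounds shown leave open how a nitrile or a methyl in the place of the trifluoromethyl, or a longer chain on the oxygen, would read in this assay. They also leave open whether compound 2, compound 3 and compound 4 would differ in the strength of their effect at any other concentration, which a read-out at one concentration cannot tell.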